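Series notes: thiazole in place of pyrazine at the biaryl position

A few compounds are considered here, and "the series" means these few. Any claim that something is new, unique, unknown or untested is made for them only; others in the source may bear on it.

Of the compounds shown here, three of one core have been measured in a functional assay for activation of Alpha-1A adrenergic receptor (Homo sapiens), read by calcium flux; a higher number here means that more compound is needed for the effect, a lower number that less compound is needed. Compound 1 `c1cncc(-c2ccccc2OCC2=NCCN2)c1` gives 2 nM. Compound 2 `c1ccc(-c2cnccn2)c(OCC2=NCCN2)c1` gives 2.51 nM. Compound 3 `Cc1ccc(-c2ccccc2OCC2=NCCN2)s1` gives 25.1 nM. Compound 2 thus stands second highest of the three numbers: the step of a 1.3-fold higher number from compound 1 to compound 2 (0.10 log units; within the scatter) lies within the scatter, while the step of a 10-fold higher number from compound 2 to compound 3 (1.00 log units; beyond the scatter) is beyond it, as is a 13-fold higher number from compound 1 to compound 3 (1.10 log units; beyond the scatter).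

Compound 4 `Cc1csc(-c2ccccc2OCC2=NCCN2)n1` is not yet measured. It differs from compound 2 in one place: 4-methyl-1,3-thiazol-2-yl in place of pyrazin-2-yl on an aromatic carbon. The step from compound 2 to compound 3 bears on this change most directly, since in both cases a six-membered aromatic ring with 2 hetero atoms gives way to a five-membered aromatic ring holding sulfur; the step from compound 1 to compound 2 shows that exchanging one six-membered aromatic ring with hetero atoms for another changed little. The entering 4-methyl-1,3-thiazol-2-yl keeps one nitrogen and 2 hydrogen-bond acceptors, so a rise smaller than that seen for compound 3 is expected. An increase of about a 3.2-fold higher number from compound 2 to compound 4 (0.50 log units; beyond the scatter) is estimated. Compound 4 is therefore expected to give 8 nM in this assay, with a range from 2.5 nM to 25 nM.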

Compound 4, half-maximal effective concentration: 25.1 nM
Compound 4: middle estimate off by 3.1-fold (0.50 log units), on the low side, and the stated range ends below it.
By their numbers in this assay, from the lowest: compounds 1 and 2 (each within the scatter of the next); then compounds 3 and 4 (each within the scatter of the next).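

In this assay the change to 4-methyl-1,3-thiazol-2-yl costs as much as the earlier change to 5-methylthiophen-2-yl, with a 10-fold higher number from compound 2 to compound 4 (1.00 log units; beyond the scatter) and then no change at the digits printed from compound 3 to compound 4 (within the scatter) between the two five-membered groups, so the ring nitrogen of the thiazole brings no visible gain over the thiophene. The gap also holds against the other six-membered group, with a 13-fold higher number from compound 1 to compound 4 (1.10 log units; beyond the scatter) on record. All four compounds now divide by ring size at this aromatic carbon, and none goes against that division.

Both five-membered groups carry a methyl, so ring size and methyl remain unseparated, and an unsubstituted 1,3-thiazol-2-yl or a methyl-bearing pyridine would be needed to tell them apart. No data at hand account for the division.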